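The source may report more compounds than this note shows. Statements on the series, on what has been measured and on what is new or still open speak of the compounds shown alone.

In a functional assay on Ehrlich cells (Mus musculus) for cytotoxicity, tested at 25 ug/mL (on this read-out higher numbers stand for a stronger effect at the one concentration tested and lower numbers for a weaker effect), compound 2 `COc1cc(N2C(N)=C(C#N)C(c3ccc(O)cc3)C3=C2CC(C)(C)CC3=O)cc(OC)c1OC` gives 20%. Compound 1 `COc1cc(N2C(N)=C(C#N)C(c3cccc([N+](=O)[O-])c3)C3=C2CC(C)(C)CC3=O)cc(OC)c1OC` gives 20%, so that no change at the digits printed from compound 1 to compound 2 (within the scatter), whereas compound 3 `COc1cc(N2C(N)=C(C#N)C(c3ccccc3O)C3=C2CC(C)(C)CC3=O)cc(OC)c1OC` gives 0% and a number 20 percentage points lower from compound 2 to compound 3 (beyond the scatter). Compound 4 `COc1ccc(C2C(C#N)=C(N)N(c3cc(OC)c(OC)c(OC)c3)C3=C2C(=O)CC(C)(C)C3)cc1` differs from compound 2 by methyl in place of hydrogen on an oxygen on an aromatic ring. For the measured compounds named here, none of the measured steps touches a hydroxy group itself; they exchange the whole aryl group. Exchanging the 3-nitrophenyl for the 4-hydroxyphenyl gave no change at the digits printed from compound 1 to compound 2 (within the scatter), and only the 2-hydroxyphenyl of compound 3 pulled the value down. Capping the oxygen of the 4-hydroxyphenyl with methyl is therefore expected to leave the read-out within the scatter, no change at the digits printed from compound 2 to compound 4 (within the scatter). Compound 4 is estimated at 20%, expected between 5% and 35%.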

Compound 4, a percentage reported as activity, at one concentration (the size of the read-out at that concentration, not a potency): 1%
Estimate against measurement, compound 4: 19 percentage points above; the whole stated range lies above it.
By their numbers in this assay, from the lowest: compounds 3 and 4 (each within the scatter of the next); then compounds 1 and 2 (each within the scatter of the next).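

In this assay the hydrogen on the oxygen of the 4-hydroxyphenyl turns out not to be a neutral place: methyl there gives a number 19 percentage points lower from compound 2 to compound 4 (beyond the scatter) on its own. The 4-methoxyphenyl also gives a number 19 percentage points lower from compound 1 to compound 4 (beyond the scatter) and so joins the 2-hydroxyphenyl at the low end, with a number 1 percentage points higher from compound 3 to compound 4 (within the scatter) as the step between them. Thus the 2-hydroxyphenyl is no longer the only aryl group with a low reading, and nothing available accounts for this. As far as these compounds go, whether ethyl on that oxygen, or an amine in place of the hydroxy group, would read like compound 2 or like compound 4 stays open.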